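This account rests on a few compounds, and the source may have more. Where it says the series, first, only, none or still open, it means among the compounds named here.

Compound 1 `O=S(=O)(c1cccc(Cl)c1)n1ccc2c(N3CCNCC3)cccc21` gives 0.251 nM in an assay on HeLa cells for displacement of a labelled ligand from 5-hydroxytryptamine receptor 6 (Homo sapiens) (a higher number here means a weaker inhibitor, a lower number a stronger inhibitor), the lowest of the three numbers recorded so far. Compound 3 `Cc1cn(S(=O)(=O)c2cccc(Cl)c2)c2cccc(N3CCNCC3)c12` gives 0.631 nM in this assay, and compound 2 `O=S(=O)(c1ccccn1)n1ccc2c(N3CCNCC3)cccc21` gives 1 nM. Compound 4 `Cc1cc2c(N3CCNCC3)cccc2n1S(=O)(=O)c1cccc(Cl)c1` differs from compound 1 by methyl in place of hydrogen on an aromatic carbon. The step that bears on this change is the one where a methyl likewise replaced a hydrogen on an aromatic carbon of the shared core: a 2.5-fold higher number from compound 1 to compound 3 (0.40 log units; beyond the scatter). The step of a 4.0-fold higher number from compound 1 to compound 2 (0.60 log units; beyond the scatter) concerns the sulfonyl substituent and does not bear on it. Because a 2.5-fold higher number from compound 1 to compound 3 (0.40 log units; beyond the scatter) was modest, a small weakening is expected here too, namely a 2.0-fold higher number from compound 1 to compound 4 (0.30 log units; within the scatter). Compound 4 is therefore estimated at 0.5 nM, within a range of 0.2 nM to 1.6 nM.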

Compound 4, inhibition constant: 0.398 nM
Estimate against measurement, compound 4: 1.3-fold (0.10 log units) above; the range from low to high includes it.
By their numbers in this assay, from the lowest: compounds 1, 4, 3 and 2 (each within the scatter of the next, the first and the last beyond it).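

On an aromatic carbon of the five-membered ring, next to the ring nitrogen, methyl in place of hydrogen leaves no readable change in this assay (a 1.6-fold higher number from compound 1 to compound 4 (0.20 log units; within the scatter)). The earlier methyl step on the shared core (a 2.5-fold higher number from compound 1 to compound 3 (0.40 log units; beyond the scatter)) lay beyond the scatter, so a methyl on this core does not always give a readable step. No measurement shown accounts for this result.

Going by these compounds, whether an ethyl, a primary amine or a carboxylic acid at this carbon would also leave the number unchanged stays open. So does the effect of this methyl alongside pyridin-2-yl on the sulfonyl sulfur.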